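This account rests on a few compounds, and the source may have more. Where it says the series, first, only, none or still open, it means among the compounds named here.

Compound 1, `N=C(NCc1ccc(O)cc1)[C@@H]1CCC(=O)N1Cc1ccccc1`, gives 19.8% in a functional assay on SH-SY5Y cells (Homo sapiens) for cytotoxicity, read by MTT assay, with stated times of 8 h, 30 min and 12 h, tested at 0.05 uM; on this read-out lower numbers stand for a weaker effect and higher numbers for a stronger effect at the one concentration tested.
Compound 2, `COc1ccc(CNC(=N)[C@@H]2CCC(=O)N2Cc2ccccc2)cc1`, gives 7.1% in this assay.
Compound 3, `N=C(NCc1ccc(O)cc1)[C@@H]1CCC(=O)N1Cc1ccc([N+](=O)[O-])cc1`, gives 25.9% in this assay.

Compound 2 differs from compound 1 by methyl in place of hydrogen on an oxygen on an aromatic ring, and in this assay the step is a number 12.7 percentage points lower from compound 1 to compound 2 (beyond the scatter). Compound 3 carries a different core from compound 1; the two cores differ by nitro in place of hydrogen on an aromatic carbon, and the step in this assay is a number 6.1 percentage points higher from compound 1 to compound 3 (within the scatter), so compounds 1 and 3 cannot be told apart on this read-out, while the gap from compound 3 to compound 2 is beyond the scatter.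

Compound 4, `COc1ccc(CNC(=N)[C@@H]2CCC(=O)N2Cc2ccc([N+](=O)[O-])cc2)cc1`, has not yet been measured in this assay. It differs from compound 3 by methyl in place of hydrogen on an oxygen on an aromatic ring. Going by the values given here, this is the same change as the one from compound 1 to compound 2, made on the same place in the same words, but now on the core of compound 3. The change has been seen only once among these compounds, so its size rests on a single pair.

For compound 4 the step is expected to be a number 12.9 percentage points lower from compound 3 to compound 4 (beyond the scatter), because a number 12.7 percentage points lower from compound 1 to compound 2 (beyond the scatter) is the same change made on the same place, and because a number 6.1 percentage points higher from compound 1 to compound 3 (within the scatter) shows that the starting points lie within the scatter of each other. Compound 4 is therefore estimated at 13% in this assay, with a range from 3% to 24% to allow for the one-pair basis.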

Compound 4, a percentage reported as activity, at one concentration (the size of the read-out at that concentration, not a potency): 14.3%
Compound 4: middle estimate off by 1.3 percentage points, on the low side; the measured number falls inside the stated range.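

In this assay, the change from 4-hydroxybenzyl to 4-methoxybenzyl on the core of compound 3 gives a step of a number 11.6 percentage points lower from compound 3 to compound 4 (beyond the scatter), and this step matches the one already seen on the core of compound 1: the same change on two cores in this assay, a number 12.7 percentage points lower (beyond the scatter) from compound 1 to compound 2 and a number 11.6 percentage points lower (beyond the scatter) from compound 3 to compound 4, 1.1 percentage points apart, within the scatter of two such steps. The nitro change, read on the other pair, gives a step of a number 7.2 percentage points higher from compound 2 to compound 4 (within the scatter), which leaves that pair indistinguishable on this read-out, just as compounds 1 and 3 are, and the two steps agree: the same change on two cores in this assay, a number 6.1 percentage points higher (within the scatter) from compound 1 to compound 3 and a number 7.2 percentage points higher (within the scatter) from compound 2 to compound 4, 1.1 percentage points apart, within the scatter of two such steps. Together the four compounds show that the two changes add up without visible interference on these two cores, but this is only one pair of steps for each change at a single concentration, so it shows neither that the methoxy step would hold on a further core nor why it occurs.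

The compounds shown leave open whether a longer chain on the oxygen, such as ethoxy, would give a step of similar size to that of methyl. They also leave open whether an amine or a carboxylic acid in place of nitro would behave as nitro does on these cores.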